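A few compounds are considered here, and "the series" means these few. Any claim that something is new, unique, unknown or untested is made for them only; others in the source may bear on it.

Measured compounds in a functional assay on A-431 cells (Homo sapiens) for cytotoxicity, read by MTT assay, with a stated time of 72 h; on this read-out lower numbers stand for stronger inhibition and higher numbers for weaker inhibition:

compound 1 `N/C(=N\NC(=S)N1CCCCCC1)c1ccccn1` — 3000 nM
compound 2 `N/C(=N\NC(=S)N1CCSCC1)c1ccccn1` — 6700 nM
compound 3 `N/C(=N\NC(=S)N1CCSCC1)c1ccc(F)cn1` — 1200 nM

Compound 1 and compound 2 share the pyridine-bearing amidrazone thiosemicarbazide part and differ in the saturated ring attached to the thiocarbonyl; the difference between the two cores is not broken down here. Their values show compound 2 giving a higher number than compound 1 in this assay, a gap beyond the usual scatter.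

Within the core of compound 2, one change has been measured: fluoro in place of hydrogen on an aromatic carbon. This gave a 5.6-fold lower number from compound 2 to compound 3 (0.75 log units; beyond the scatter), taking compound 3 to the lowest number of the three.

Compound 4 `N/C(=N\NC(=S)N1CCCCCC1)c1ccc(F)cn1` carries the same change on the core of compound 1: fluoro in place of hydrogen on an aromatic carbon. The place of the change is the same in both pairs, so this is the same change. For the measured compounds named here, the expectation for compound 4 rests on the single precedent a 5.6-fold lower number from compound 2 to compound 3 (0.75 log units; beyond the scatter), and the step is expected to be a 3.8-fold lower number from compound 1 to compound 4 (0.57 log units; beyond the scatter). Going by the values given here, with only one earlier example the expected step is kept somewhat smaller than that precedent. The number expected for compound 4 in this assay is 800 nM, with a range from 300 nM to 2000 nM.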

Compound 4, half-maximal inhibitory concentration: 1000 nM
For compound 4 the middle estimate is 1.3-fold (0.10 log units) below the measured one; the measured number falls inside the stated range.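

In this assay, fluoro in place of hydrogen on an aromatic carbon, two atoms from the ring nitrogen, gives a 3.0-fold lower number from compound 1 to compound 4 (0.48 log units; beyond the scatter). Set beside the earlier step, the change carries over between these two cores, with the same direction and no size difference that stands out from the scatter: the same change on two cores in this assay, a 5.6-fold lower number (0.75 log units; beyond the scatter) from compound 2 to compound 3 and a 3.0-fold lower number (0.48 log units; beyond the scatter) from compound 1 to compound 4, 1.9-fold (0.27 log units) apart, within the scatter of two such steps. For the compounds shown here, this rests on only two matched pairs, one place on the ring and one cell line, so it shows transfer between the core of compound 1 and the core of compound 2 but sets no rule for other saturated rings and gives no reason for the lower numbers.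

Still open, from the compounds shown here alone, is whether the lower number is particular to fluoro, or whether chloro, methoxy, a nitrile or an amine at the same place would give a similar step. Also open, going by these compounds, is whether fluoro elsewhere on the aromatic ring would carry across both cores in the same way.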